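Nitro to fluoro on the fused ring: compound 4

A few compounds are considered here, and "the series" means these few. Any claim that something is new, unique, unknown or untested is made for them only; others in the source may bear on it.

Compound 1 `O=[N+]([O-])c1ccc2c(c1)S(=O)(=O)NC(NC1CCC1)=N2` gives in a functional assay for agonist activity at sulfonylurea receptor 1, Kir6.2 (Homo sapiens) (on this read-out lower numbers stand for smaller maximal responses and higher numbers for larger maximal responses), a value of 30.9%, the lowest of the three numbers in hand. Compound 2 `O=S1(=O)N=C(NC2CCC2)Nc2ccccc21` gives 109% and compound 3 `O=S1(=O)N=C(NC2CCC2)Nc2ccc(Cl)cc21` gives 137%, both beyond the scatter above compound 1. Compound 4 `O=S1(=O)NC(NC2CCC2)=Nc2ccc(F)cc21` has not been measured; it differs from compound 1 in one place: fluoro in place of nitro on an aromatic carbon. Within the data shown here, no measured step replaces a nitro group, so the bearing of the measured data is indirect. Compound 1 and compound 2 carry nitro and hydrogen on the aromatic carbon, and their two values lie far apart. Among the measured compounds shown here, the one measured step, a number 28 percentage points higher from compound 2 to compound 3 (beyond the scatter), shows that a chloro group on the aromatic carbon moved the maximum only modestly upward. Compound 4 is therefore expected to show a number 84.1 percentage points higher from compound 1 to compound 4 (beyond the scatter). That expected value would place compound 4 near compound 2 and compound 3 rather than near compound 1. The estimate for compound 4 is 115%, with a range from 80% to 150%.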

Compound 4, largest response reached (reported as maximum), in percent of the reference or control that the assay uses: 136%
Beside the measured number, compound 4's estimate is 21 percentage points below it; measured number inside the range.
By their numbers in this assay, from the lowest: compound 1; then compound 2; then compounds 4 and 3 (each within the scatter of the next).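

Fluoro in place of nitro on this aromatic carbon, para to a fused ring, gives a number 105.1 percentage points higher from compound 1 to compound 4 (beyond the scatter) in this assay, the first measured step that removes the nitro group and a large one. With fluoro, compound 4 reaches 136% and with chloro, compound 3 reaches 137%, two values within the scatter of each other, so among the compounds shown only the nitro-bearing compound 1 sits at the low end of the series. No measurement available here accounts for the size of this step.

Whether the low maximum belongs to nitro alone stays open, since the groups shown at this position are limited to nitro, hydrogen, chloro and fluoro. An amine, a nitrile or a methoxy group on the same carbon could show whether other groups fall with compound 1 or with compound 4.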